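Inverting one ring stereocentre of compound 1

A few compounds are considered here, and "the series" means these few. Any claim that something is new, unique, unknown or untested is made for them only; others in the source may bear on it.

In a functional assay on MIA PaCa-2 cells (Homo sapiens) for inhibition, read by MTT assay, with a stated time of 3 days (on this read-out higher numbers stand for weaker inhibition and lower numbers for stronger inhibition), compound 1 (`CCOC(=O)[C@@H]1CCC[C@@H](S(=O)(=O)c2ccc(S(=O)(=O)N(CC)CC)cc2)C1`) gives 5000 nM, and compound 2 (`CC(C)c1noc(N2CCN(C(=O)[C@@H]3CCCN(S(=O)(=O)c4ccc(S(=O)(=O)C5CCC5)cc4)C3)CC2)n1`) gives 20 nM. For the measured compounds named here, the number for compound 1 is the higher of the two so far, and the gap between them lies beyond the scatter. Compound 3 (`CCOC(=O)[C@@H]1CCC[C@H](S(=O)(=O)c2ccc(S(=O)(=O)N(CC)CC)cc2)C1`) is still unmeasured. It has the same atoms and bonds as compound 1: the two compounds have the same atoms and bonds and differ only in configuration as drawn: 1 of 2 stereo elements differ; a stereocentre at a saturated ring carbon is drawn R in compound 1 and S in compound 3, with a stereocentre at a saturated ring carbon drawn R in compound 1 and S in compound 3. Going by the values given here, no measured pair shows what such a change does in this assay. The expected step, a 1.3-fold lower number from compound 1 to compound 3 (0.10 log units; within the scatter), stays within the scatter, in neither direction. For compound 3 the estimate is 4000 nM, with a range of 1000 nM to 12000 nM.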

Compound 3, half-maximal inhibitory concentration: > 10000 nM
Compound 3 gave a limit, no number (the forecaster's own chance of this, stated with the estimate: 15%); middle value at least 2.5-fold (0.39 log units) away from the limit.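

In this assay compound 3 gives a limit, > 10000 nM, not a number. The step reads an at least 2.0-fold higher number from compound 1 to compound 3 (0.30 log units; that floor lies within the scatter), so inverting this saturated ring carbon brings no lower number, yet the floor alone does not separate the two configurations. This is the first pair here to isolate configuration: the fact that compounds 1 and 3 differ only in the configuration as drawn

From the compounds shown here alone, how far the true step lies beyond its floor stays open. Also open, going by these compounds, is whether the same inversion would read alike with a carboxylic acid in place of the ethyl ester.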